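Propylamino for Thiophen-3-yl: a Solubility Outlook

The compounds below may be only part of what the source reports. "The series", "measured", "known", "first", "only" and "open" are said of these compounds alone.

Compound 1 `CN1CCC(C(=O)N2Cc3c(NC(=O)c4ccsc4)n[nH]c3C2(C)C)CC1` and two companions sharing its core were measured in a physicochemical assay for solubility, at pH 7; on this read-out lower numbers stand for lower solubility and higher numbers for higher solubility. Compound 1 gives > 225000 nM, which is a limit of the assay. Compound 2 `CN(C)CC(=O)Nc1n[nH]c2c1CN(C(=O)C(C)(C)C)C2(C)C` likewise gives > 225000 nM, again only a limit. Going by the values given here, compound 3 `CC1(C)c2[nH]nc(NC(=O)c3ccc(F)cc3)c2CN1C(=O)N1CCN(c2ccccc2)CC1` is the one with a number, giving 55000 nM in this assay. Compound 1 thus stands at the limit of > 225000 nM in this assay, at which 2 of the 3 values shown sit, and the readings of compound 1 and compound 2 show no more than that. Among the compounds with values here, no pair of measured compounds differs in a single place, so no measured step is available to guide the change under consideration. Compound 4 `CCCNC(=O)Nc1n[nH]c2c1CN(C(=O)C1CCN(C)CC1)C2(C)C` differs from compound 1 by propylamino in place of thiophen-3-yl on a carbonyl carbon. The expected step, a step that the limit leaves unreadable from compound 1 to compound 4, is small and lies within the usual scatter or, if anything, upward. Compound 4 is therefore expected to give about 250000 nM in this assay, within a range from 100000 nM to 600000 nM, and it may well again return only a limit.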

Compound 4, solubility: > 225000 nM
Compound 4 was reported as a limit (the forecaster's own chance of this, stated with the estimate: 70%); the middle value is on the limit's open side.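

In this assay compound 1 and compound 4 both sit at a limit, so no step can be read between the two compounds: the limit of > 225000 nM in this assay, at which 3 of the 4 values shown sit.
As far as these compounds go, how far either compound lies past that limit stays open, and with it the size of the change from thiophen-3-yl to propylamino on a carbonyl carbon.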